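A carboxyethyl swap: compound 3 to compound 4

The compounds below may be only part of what the source reports. "The series", "measured", "known", "first", "only" and "open" are said of these compounds alone.

Measured in a functional assay on MCF7 cells (Homo sapiens) for antiproliferative activity, read by MTT assay, with a stated time of 24 h; on this read-out higher numbers stand for weaker inhibition and lower numbers for stronger inhibition
compound 1 `CCn1c(C(=O)N[C@H](CO)CCO)ccc1C(CC)(CC)c1ccc(OCS(=O)(=O)c2ccccc2)c(C)c1` gives 28500 nM
compound 2 `CCn1c(C(=O)NCC(=O)O)ccc1C(CC)(CC)c1ccc(OCS(=O)(=O)c2ccccc2)c(C)c1` gives 33100 nM
compound 3 `CCn1c(C(=O)N[C@H](C)C(=O)O)ccc1C(CC)(CC)c1ccc(OCS(=O)(=O)c2ccccc2)c(C)c1` gives > 50000 nM as a limit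

Compound 3 holds a value of > 50000 nM that is a limit of the assay and not a number. Compound 4 `CCn1c(C(=O)NCCC(=O)O)ccc1C(CC)(CC)c1ccc(OCS(=O)(=O)c2ccccc2)c(C)c1` differs from compound 3 by 2-carboxyethyl in place of 1-carboxyethyl on an amide-type nitrogen with 2-carboxyethyl in place of 1-carboxyethyl on an amide-type nitrogen. Going by the values given here, three measured steps bear on this change. The closest is an at least 1.5-fold higher number from compound 2 to compound 3 (0.17 log units; that floor lies within the scatter) and it concerns the same 1-carboxyethyl group. The others are an at least 1.7-fold higher number from compound 1 to compound 3 (0.24 log units; that floor lies within the scatter) and a 1.2-fold higher number from compound 1 to compound 2 (0.06 log units; within the scatter) and none of the three is shown beyond the scatter. A step in this assay is therefore expected to be small, toward a lower number if there is one, and perhaps none beyond the scatter. The nearest guide is compound 2 with 33100 nM as its value. A limit reading also remains possible for compound 4. The expected step is an at least 1.3-fold lower number from compound 3 to compound 4 (0.11 log units; that floor lies within the scatter) as estimated here. Compound 4 is estimated at 38000 nM with an expected range from 20000 nM to 60000 nM as its span.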

Compound 4, half-maximal inhibitory concentration: > 50000 nM
Compound 4 was reported as a limit (the forecaster's own chance of this, stated with the estimate: 35%); at least 1.3-fold (0.11 log units) between middle value and limit.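

In this assay compound 4 gives > 50000 nM, which is a limit of the assay and not a number. The step between compound 3 and compound 4 cannot be read, because both compounds sit at the same limit: the limit of > 50000 nM in this assay, at which 2 of the 4 values shown sit.

The other two comparisons give an at least 1.5-fold higher number from compound 2 to compound 4 (0.17 log units; that floor lies within the scatter) and an at least 1.7-fold higher number from compound 1 to compound 4 (0.24 log units; that floor lies within the scatter), so the 2-carboxyethyl group on the amide-type nitrogen, like the 1-carboxyethyl group, shows no step beyond the scatter.

The compounds shown leave open where compound 3 and compound 4 truly lie past the limit, and so whether the two carboxyethyl groups differ at all. They also leave open whether an amine in place of the carboxylic acid, or a longer chain carrying the carboxylic acid, would move the number beyond the scatter.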